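Propargyloxymethyl in Place of Chlorobenzyl: Expected Tolerance

This account rests on a few compounds, and the source may have more. Where it says the series, first, only, none or still open, it means among the compounds named here.

Measured so far:
compound 1 `O=C1c2ccccc2N(Cc2ccc(Cl)cc2)S(=O)(=O)N1Cc1ccccc1` gives > 5000 nM
compound 2 `O=C1c2ccccc2N(Cc2ccc(Cl)cc2)S(=O)(=O)N1Cc1ccc(Cl)cc1` gives > 50000 nM

In a functional assay on HEL cells (Homo sapiens) (a lower number here means that less compound is tolerated, a higher number that more compound is tolerated), neither value is a number; both are limits of the assay. For compound 1 the value > 5000 nM is such a limit (the limit of > 5000 nM in this assay, at which 1 of the 2 values shown sits). For compound 2 the value > 50000 nM is likewise a limit (the limit of > 50000 nM in this assay, at which 1 of the 2 values shown sits). Going by the values given here, the only measured step, a step that the two limits leave unreadable from compound 1 to compound 2, therefore cannot be read in size, and its change, a chloro in place of hydrogen on an aromatic carbon, does not touch the change considered next. Compound 3 `C#CCOCN1c2ccccc2C(=O)N(Cc2ccccc2)S1(=O)=O` differs from compound 1 by propargyloxy in place of 4-chlorophenyl on a saturated chain carbon bound to a sulfonamide nitrogen in a ring. Among the compounds with values here, no measured step covers this change, so, resting on compound 1 and its limit > 5000 nM, the expected step that the limit leaves unreadable from compound 1 to compound 3 is set at none beyond the scatter. Compound 3 is thus expected to give 20000 nM, with a range of 5000 nM to 100000 nM, and most likely to be reported again only as a limit.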

Compound 3, minimum cytotoxic concentration: 140000 nM
Compound 3: middle estimate off by 7.0-fold (0.85 log units), on the low side, outside the stated range (above it).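

In this assay compound 1 gives > 5000 nM as a limit and not a number, so the step from it to compound 3 cannot be read in size. The compounds shown leave open whether propargyloxy in place of 4-chlorophenyl changes the tolerated concentration at all, and by how much.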